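This account rests on a few compounds, and the source may have more. Where it says the series, first, only, none or still open, it means among the compounds named here.

Compound 1 `CCCN(C[C@H]1Cc2c(cccc2N2CCNCC2)CN1)[C@H]1CCCc2cccnc21` is the more potent of the two compounds measured in a functional assay on CCRF-CEM cells for antagonist activity at C-X-C chemokine receptor type 4 (Homo sapiens), read by calcium flux, with stated times of 25 min and 90 s (a lower number here means a stronger inhibitor, a higher number a weaker inhibitor), where compound 1 gives 32.2 nM. Compound 2 `CN(C[C@@H]1Cc2c(cccc2N2CCNCC2)CN1)[C@H]1CCCc2cccnc21` carries a methyl group on the amine nitrogen in place of the propyl of compound 1, and also differs from it in the configuration of one ring carbon; in this assay compound 2 gives 313 nM, a weaker result that lies beyond the scatter. Within the data shown here, since compound 2 differs from compound 1 in two places, no single-change step between them is given, and only their two values can be set side by side.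

Compound 3 `CCN(C[C@H]1Cc2c(cccc2N2CCNCC2)CN1)[C@H]1CCCc2cccnc21` has not yet been measured. It differs from compound 1 by hydrogen in place of methyl on a saturated chain carbon, two bonds along the chain from an amine nitrogen. With only two data points and no step between compounds that differ in one place, the expectation for compound 3 is taken from the direction shown by compound 1 and compound 2: a shorter chain on the amine went with a weaker result, so a modest loss of potency, with the expected step of a 2.0-fold higher number from compound 1 to compound 3 (0.31 log units; beyond the scatter), is the estimate. Compound 3 is therefore expected to give about 65 nM in this assay, with a range from 25 nM to 200 nM.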

Compound 3, half-maximal inhibitory concentration: 14.8 nM
Compound 3: the middle estimate sits 4.4-fold (0.64 log units) above what was measured, and the stated range ends above it.
By their numbers in this assay, from the lowest: compound 3; then compound 1; then compound 2.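

Among these compounds, the change from propyl to ethyl on the amine nitrogen, with hydrogen in place of methyl on a saturated chain carbon, two bonds along the chain from an amine nitrogen, gives the first reading of this position through a change in one place only: in this assay there is a step of a 2.2-fold lower number from compound 1 to compound 3 (0.34 log units; beyond the scatter) in the direction of a stronger inhibitor. At this position, then, the propyl chain is not needed for potency in the core of compound 1, and its outermost methyl can go with a gain rather than a loss, so a shorter chain does not by itself bring a weaker result. Nothing given here accounts for this gain, so the step stands as an observation without an explanation.

The compounds shown leave open how far this trend runs, since a hydrogen, an isopropyl group or a butyl chain on the same nitrogen has no value here. They also leave open how much of the weaker result of compound 2 belongs to its methyl group and how much to the configuration of its ring carbon, as these two differences are never separated.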